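The source may report more compounds than this note shows. Statements on the series, on what has been measured and on what is new or still open speak of the compounds shown alone.

Measured so far in a physicochemical assay for lipophilicity; a higher number here means a more lipophilic compound, a lower number a more polar compound:
compound 1 `CCCCC1(c2ccccc2)NC(=O)N(C)C1=O` gives 3.01;
compound 2 `CCCCCC1(c2ccccc2)NC(=O)NC1=O` gives 2.96;
compound 3 `CCCCCCC1(c2ccccc2)NC(=O)NC1=O` gives 3.4.

Compound 2 has the lowest of the three numbers in this assay, though its gap to compound 1 is within the scatter, so the two cannot be ordered; compound 3 stands clearly higher, as a number 0.44 log units higher from compound 2 to compound 3 (beyond the scatter) shows.

Compound 4 `CCCCCCCCCC1(c2ccccc2)NC(=O)NC1=O` is not yet measured. It differs from compound 2 by a single change: butyl in place of hydrogen on a saturated chain carbon, five bonds along the chain from a saturated ring carbon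

Within the data shown here, the one measured step that bears on this change is a number 0.44 log units higher from compound 2 to compound 3 (beyond the scatter), a modest rise beyond the scatter. Compound 4 carries a longer chain at the same place, so a rise in this assay is expected, and a larger one than the measured step, since the chain extends further. Compound 1 and compound 2 do not bear on it.

For compound 4 the value expected in this assay is 4.6, with a range from 4.1 to 5.1. This estimate means a step of a number 1.64 log units higher from compound 2 to compound 4 (beyond the scatter), upward, beyond the scatter.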

Compound 4, partition coefficient: 4.96
Compound 4: the middle estimate sits 0.36 log units below what was measured, within the range that was stated.
By their numbers in this assay, from the lowest: compounds 2 and 1 (each within the scatter of the next); then compound 3; then compound 4.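

Butyl in place of hydrogen at this place gives a number 2.00 log units higher from compound 2 to compound 4 (beyond the scatter) in this assay, a large step where methyl gave only a modest one, so the number climbs along compound 2, compound 3 and compound 4 with no levelling off up to this chain. Most of that rise lies beyond compound 3: propyl in place of hydrogen, six bonds along the chain from a saturated ring carbon, gives a number 1.56 log units higher from compound 3 to compound 4 (beyond the scatter) and is itself a large step. No measurement at hand gives a reason for the size of these steps.

From the compounds shown here alone, whether the number keeps climbing with a longer chain than that of compound 4 remains open. So does how a branched chain, an amine or a carboxylic acid at the same place would read in this assay on this shared core.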